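This account rests on a few compounds, and the source may have more. Where it says the series, first, only, none or still open, it means among the compounds named here.

Going by the values given here, compound 2 `CC(CC(=O)O)CC(=O)c1c(CCCCCC(F)(F)F)n(C)c2ccc(Cl)cc12` gives 38 nM in a functional assay for antagonist activity at Oxoeicosanoid receptor 1 (Homo sapiens), read by fluorescence and calcium flux, with stated times of 2 min and 1 min (a lower number here means a stronger inhibitor, a higher number a weaker inhibitor), and stands highest of the two numbers so far; compound 1 `CC(CC(=O)O)CC(=O)c1c(CCCCCCc2ccccc2)n(C)c2ccc(Cl)cc12` gives 0.28 nM. Among the compounds with values here, the one measured step, a 140-fold higher number from compound 1 to compound 2 (2.13 log units; beyond the scatter), bears directly on the present change, which runs the same way back: compound 3 `CC(CC(=O)O)CC(=O)c1c(CCCCc2ccccc2)n(C)c2ccc(Cl)cc12` carries phenyl in place of 2,2,2-trifluoroethyl on a saturated chain carbon, four bonds along the chain from an aromatic carbon. A large drop in the number is therefore expected, though the chain between the core and the phenyl is shorter than in compound 1, so full reversal is not assumed. For compound 3 the estimate is 1.2 nM (range 0.25 nM to 6 nM), a step of a 32-fold lower number from compound 2 to compound 3 (1.50 log units; beyond the scatter).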

Compound 3, half-maximal inhibitory concentration: 38 nM
Compound 3: middle estimate off by 32-fold (1.50 log units), on the low side, outside the stated range (above it).
By their numbers in this assay, from the lowest: compound 1; then compounds 2 and 3 (each within the scatter of the next).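

In this assay, a terminal phenyl does not by itself give a low number: phenyl in place of 2,2,2-trifluoroethyl at this place brings no gain (no change at the digits printed from compound 2 to compound 3 (within the scatter)). Shortening the chain that carries the phenyl costs as much as losing the phenyl in compound 2 (a 140-fold higher number from compound 1 to compound 3 (2.13 log units; beyond the scatter)), so among these three compounds only compound 1, with the longer chain to its phenyl, has the low number. No measurement shown here explains this.

Still open, on these data alone, is how the number behaves with a phenyl on a chain longer than that of compound 1. A cyclohexyl at the chain end also remains to be compared with phenyl.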